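Urea series: aryl replacement on the urea nitrogen

The source may hold more compounds than are shown below. What is called first, only, known or untested is meant among the compounds shown, and "the series" means these compounds.

Measured so far:
compound 1 `CN(C)C1(Cc2ccccc2)CCN(c2cc(C(F)(F)F)ccc2CNC(=O)Nc2ccc(NS(C)(=O)=O)c(F)c2)CC1` — "not active" (no number reported)
compound 2 `CN(C)C1(Cc2ccccc2)CCN(c2cc(C(F)(F)F)ccc2CNC(=O)Nc2cccc3c(=O)[nH]ccc23)CC1` — 43.7 nM

In an assay on CHO cells for agonist activity at transient receptor potential cation channel subfamily V member 1 (Homo sapiens), read by scintillation counting, with a stated time of 5 min, in the presence of a further agent that is not named here (on this read-out higher numbers stand for an effect only at larger amounts of compound and lower numbers for an effect already at smaller amounts), compound 1 gives "not active" (no number reported), with no number reported. In this assay, going by the values given here, compound 2 gives 43.7 nM, the only number in the set; it therefore stands alone, with one further entry that carries no number beside it.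

Compound 3 `CN(C)C1(Cc2ccccc2)CCN(c2cc(C(F)(F)F)ccc2CNC(=O)Nc2ccc3cccnc3c2)CC1` is the next member. Its change from compound 2 is a group of 10 heavy atoms (9 carbon, 1 nitrogen; one six-membered aromatic ring of carbon only, one six-membered aromatic ring with 1 hetero atom) in place of a group of 11 heavy atoms (9 carbon, 1 nitrogen, 1 oxygen; one six-membered aromatic ring of carbon only, one six-membered aromatic ring with 1 hetero atom), on an amide-type nitrogen. Among the compounds with values here, no step between two measured compounds is available to size this change. The group that leaves carries the donor and the carbonyl that compound 2 has; the quinolin-7-yl that enters keeps only an acceptor. The expectation is a step from compound 2 to compound 3 of a 5.7-fold higher number from compound 2 to compound 3 (0.76 log units; beyond the scatter), toward an effect only at larger amounts, beyond the scatter. Compound 3 is estimated at 250 nM, in the range 50 nM to 2000 nM.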

Compound 3, half-maximal effective concentration: "not active" (no number reported)
Nothing numeric was reported for compound 3; there is nothing to compare the estimate with.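

Going by these compounds alone, compound 3, like compound 1, carries no number in this assay, so no step from compound 2 to compound 3 can be read. Nothing available bears on this result. The compounds shown leave open which feature of the group on the amide-type nitrogen goes with the number of compound 2.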